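Sulfo for carboxy on a fused core: plasma inhibition

The source may hold more compounds than are shown below. What is called first, only, known or untested is meant among the compounds shown, and "the series" means these compounds.

Compound 1 `CC(C)c1ccc2c(CCCNS(=O)(=O)c3ccccc3)cc(C(=O)O)c-2cc1` gives in a functional assay (plasma) for inhibition, with Oryctolagus cuniculus as the target (a lower number here means a stronger inhibitor, a higher number a weaker inhibitor), a value of > 100000 nM, which is a limit of the assay rather than a number.
Compound 2 `CC(C)c1ccc2c(CCCCNS(=O)(=O)c3ccc(Cl)cc3)cc(C(=O)O)c-2cc1` gives in this assay a value of > 100000 nM, likewise a limit.
Compound 3 `COc1ccc(S(=O)(=O)NCCCCc2cc(C(=O)O)c3ccc(C(C)C)ccc2-3)cc1` gives in this assay a value of > 100000 nM, again a limit.

Compound 2 therefore stands at the limit of this assay, and the same holds for compound 1 and compound 3, so none of the three can be ranked against the others. Within the data shown here, the one measured step that differs in a single place, a step that the two limits leave unreadable from compound 2 to compound 3, cannot be read, because both ends sit at the limit of > 100000 nM in this assay, at which 3 of the 3 values shown sit. Compound 4 `CC(C)c1ccc2c(CCCCNS(=O)(=O)c3ccc(Cl)cc3)cc(S(=O)(=O)O)c-2cc1` differs from compound 2 by sulfo in place of carboxy on an aromatic carbon; that is, sulfo in place of carboxy on an aromatic carbon. Among the measured compounds shown here, no measured step touches this group, so nothing among the three compounds points to a move away from the limit. The estimate for compound 4 in this assay is therefore 150000 nM, with a range from 40000 nM to 600000 nM, and the expected step that the limit leaves unreadable from compound 2 to compound 4 is one of no change beyond the scatter, most likely again reported only as a limit.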

Compound 4, half-maximal inhibitory concentration: 8700 nM
Compound 4: the middle estimate sits 17-fold (1.24 log units) above what was measured; the whole stated range lies above it.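

In this assay, among these compounds, sulfo in place of carboxy on an aromatic carbon gives an at least 11-fold lower number from compound 2 to compound 4 (1.06 log units; beyond the scatter), the first change here to yield a readable value rather than a limit. The group on this carbon of the five-membered aromatic ring therefore matters to the read-out, and with only a limit for compound 2, the true step could be larger still. The earlier compounds could not show this, because none of their steps can be read: the limit of > 100000 nM in this assay, at which 3 of the 4 values shown sit.

On these data alone, how a phosphonic acid, a tetrazole or a primary amide on this carbon would compare with sulfo remains open. Also open, as far as these compounds go, is whether the same change would have a similar effect with the side chains of compound 1 and compound 3, as this rests on a single pair.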